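A few compounds are considered here, and "the series" means these few. Any claim that something is new, unique, unknown or untested is made for them only; others in the source may bear on it.

Going by the values given here, compound 2 `N#Cc1ccc(/C=N/Nc2nc(N)c3ncn([C@@H]4O[C@H](CO)[C@@H](O)[C@H]4O)c3n2)cc1` carries the only number in an assay on CHO-K1 cells for displacement of a labelled ligand from adenosine receptor A1 (Homo sapiens), read by scintillation counting, with a stated time of 60 min; a higher number here means a weaker inhibitor, a lower number a stronger inhibitor: compound 2 gives 4.1 nM. Compound 1 `CN(C)c1ccc(/C=N/Nc2nc(N)c3ncn([C@@H]4O[C@H](CO)[C@@H](O)[C@H]4O)c3n2)cc1` sits at the limit of this assay, where compound 1 reads > 10000 nM, a limit rather than a number (the limit of > 10000 nM in this assay, at which 1 of the 2 values shown sits). The step of an at least 2400-fold lower number from compound 1 to compound 2 (3.38 log units; beyond the scatter) is the only measured one. Compound 3 `Nc1nc(N/N=C/c2ccc(-n3ccnc3)cc2)nc2c1ncn2[C@@H]1O[C@H](CO)[C@@H](O)[C@H]1O` differs from compound 2 by 1H-imidazol-1-yl in place of cyano on an aromatic carbon. That single measured step was large, so a sizeable change is expected, with the direction uncertain; compound 3 is expected to show the step of a 24-fold higher number from compound 2 to compound 3 (1.39 log units; beyond the scatter). Compound 3 is estimated at 100 nM, between 10 nM and 2000 nM.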

Compound 3, inhibition constant: > 10000 nM
Compound 3 gave a limit, no number (the forecaster's own chance of this, stated with the estimate: 15%); middle value at least 100-fold (2.00 log units) from the limit.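

Replacing cyano with 1H-imidazol-1-yl, on an aromatic carbon para to a large group, gives an at least 2400-fold higher number from compound 2 to compound 3 (3.38 log units; beyond the scatter) in this assay, so a second group besides dimethylamino loses the low number seen with cyano. The step from compound 1 to compound 3 cannot be read. Of the three groups shown at this position, only cyano gives a number, and the other two end at the same limit: the limit of > 10000 nM in this assay, at which 2 of the 3 values shown sit.

From the compounds shown here alone, whether a carboxylic acid, an amide or a methyl ester here would also give a readable number remains open. Going by these compounds, the actual values of compound 1 and compound 3 also remain unknown.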